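The source may report more compounds than this note shows. Statements on the series, on what has been measured and on what is new or still open speak of the compounds shown alone.

Compound 1 `OC[C@@H](O[C@H]1CCCN(Cc2ccccc2Cc2nnco2)[C@H]1c1ccccc1)c1cc(Cl)cc(Cl)c1`: 3700 nM in an assay on isolated protein for activation of cGMP-dependent protein kinase 1 (Homo sapiens), read by ADP-Glo, with stated times of 120 min and 40 min; a higher number here means that more compound is needed for the effect, a lower number that less compound is needed.
Compound 2 `Clc1cc(Cl)cc(CO[C@H]2CCCN(Cc3ccncc3)[C@H]2c2ccccc2)c1`: > 200000 nM in this assay, a limit of the assay rather than a number.

For the measured compounds named here, compound 2 thus stands only at the assay limit, and no single-point step connects it to compound 1. Compound 3 `Clc1cc(Cl)cc(CO[C@H]2CCCN(Cc3ccc(-c4nn[nH]n4)cc3)[C@H]2c2ccccc2)c1` differs from compound 2 by 4-(2H-tetrazol-5-yl)phenyl in place of pyridin-4-yl on a saturated chain carbon bound to an amine nitrogen in a ring. Going by the values given here, no measured pair here shows the size of such a change in this assay. Since compound 2 sits at the limit, a move into the measurable range is expected, of moderate size, with wide uncertainty and a real chance that only a limit is reported again. Compound 3 is expected at 60000 nM, between 10000 nM and 200000 nM. That expectation means a step of an at least 3.3-fold lower number from compound 2 to compound 3 (0.52 log units; beyond the scatter).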

Compound 3, half-maximal effective concentration: 74000 nM
Compound 3: middle estimate off by 1.2-fold (0.09 log units), on the low side; measured number inside the range.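

In this assay, 4-(2H-tetrazol-5-yl)phenyl in place of pyridin-4-yl on a saturated chain carbon bound to an amine nitrogen in a ring gives an at least 2.7-fold lower number from compound 2 to compound 3 (0.43 log units; beyond the scatter). The group at this position therefore affects the read-out, and the change brings the series from a limit to a measured value. The step is only a minimum, because compound 2 stands at a limit: the limit of > 200000 nM in this assay, at which 1 of the 3 values shown sits.

From the compounds shown here alone, the change brings in the 2H-tetrazol-5-yl ring and the phenyl ring together, and their shares in the step remain open. A plain phenyl, or a carboxylic acid on the phenyl in place of the 2H-tetrazol-5-yl ring, would help separate them.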